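Notes on the aminopyrimidine nitrile series: compound 3 to compound 4

A few compounds are considered here, and "the series" means these few. Any claim that something is new, unique, unknown or untested is made for them only; others in the source may bear on it.

The series shares one core, seen in compound 1 `Cc1ncc2c(N)c(C#N)c(N)nc2n1`, and varies the group on the aromatic carbon of the six-membered ring. In a physicochemical assay for solubility, in phosphate buffer, with a stated time of 18 h (on this read-out higher numbers stand for higher solubility and lower numbers for lower solubility), compound 1 gives 783000 nM, compound 2 `N#Cc1c(N)nc2nc(C3CCCCC3)ncc2c1N` gives 81000 nM, and compound 3 `CC(C)(C)c1nc(-c2ccsc2)c2c(N)c(C#N)c(N)nc2n1` gives 40000 nM. Compound 3 stands lowest of the three numbers measured, with compound 2 nearest and compound 1 furthest.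

Within the data shown here, the one measured step, a 9.7-fold lower number from compound 1 to compound 2 (0.99 log units; beyond the scatter), moves the number downward by a modest amount. It shows that changing the group on this carbon of the core can shift solubility, but the change it covers is not the one now in question.

Compound 4 `CC(C)(C)c1nc(-c2ncco2)c2c(N)c(C#N)c(N)nc2n1` differs from compound 3 by 1,3-oxazol-2-yl in place of thiophen-3-yl on an aromatic carbon. Among the measured compounds shown here, no measured pair covers this kind of swap of one five-membered aromatic ring for another, so the expectation rests on the size of the steps seen so far and on the scatter of this assay.

For compound 4 the estimate is 60000 nM, with a range from 25000 nM to 150000 nM. The step this implies, a 1.5-fold higher number from compound 3 to compound 4 (0.18 log units; within the scatter), is expected to be small, upward, and close to the scatter.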

Compound 4, solubility: 50000 nM
For compound 4 the middle estimate is 1.2-fold (0.08 log units) above the measured one; the range from low to high includes it.
By their numbers in this assay, from the lowest: compounds 3, 4 and 2 (each within the scatter of the next, the first and the last beyond it); then compound 1.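

In this assay, 1,3-oxazol-2-yl in place of thiophen-3-yl gives a 1.3-fold higher number from compound 3 to compound 4 (0.10 log units; within the scatter), so at this aromatic carbon, meta to a tert-butyl group, a five-membered aromatic ring with 1 hetero atom gives way to one with 2 hetero atoms without a change that stands clear of the scatter. Among these compounds, the earlier step, a 9.7-fold lower number from compound 1 to compound 2 (0.99 log units; beyond the scatter), lies beyond the scatter but covers a different change, cyclohexyl in place of methyl, so this is the first matched reading for a swap of one five-membered aromatic ring for another, and both rings have the same count of 5 heavy atoms. No measurement available for this pair accounts for the result or links it to a property of either ring.

Still open, from the compounds shown here alone, is whether a group of another kind on this carbon, such as a primary amine, a carboxylic acid, a morpholine or a longer alkyl chain, would give a step beyond the scatter. Among the compounds shown here, also open is how the tert-butyl group and the five-membered ring each bear on the read-out, as no single-place step separates them.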